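Side-chain step from compound 3 to compound 4

A few compounds are considered here, and "the series" means these few. Any claim that something is new, unique, unknown or untested is made for them only; others in the source may bear on it.

Values in a functional assay on DU-145 cells (Homo sapiens) for cytotoxicity, read by MTT assay; on this read-out lower numbers stand for stronger inhibition and higher numbers for weaker inhibition:
- compound 1 `CCCC(O)CC(=O)O[C@H](CC=C(C)C)C1=CC(=O)c2c(O)ccc(O)c2C1=O`: > 100000 nM (a limit of the assay)
- compound 2 `CCCCC(O)CC(=O)O[C@H](CC=C(C)C)C1=CC(=O)c2c(O)ccc(O)c2C1=O`: 45300 nM
- compound 3 `CC(C)=CC[C@@H](OCC(C)O)C1=CC(=O)c2c(O)ccc(O)c2C1=O`: 16100 nM

Compound 3 holds the lowest number, with compound 2 nearest. Compound 1 reports only a limit.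

The change to compound 4 `CCCC(C)(O)CC(=O)O[C@H](CC=C(C)C)C1=CC(=O)c2c(O)ccc(O)c2C1=O` is (2-hydroxy-2-methylpentyl)carbonyl in place of 2-hydroxypropyl on an oxygen on a saturated carbon. The closest evidence runs in reverse, since a 2.8-fold lower number from compound 2 to compound 3 (0.45 log units; beyond the scatter) and an at least 6.2-fold lower number from compound 1 to compound 3 (0.79 log units; beyond the scatter) both start from carbonyl-bearing chains. An added methyl also counts, with an at least 2.2-fold lower number from compound 1 to compound 2 (0.34 log units; beyond the scatter). A modest rise in this assay is expected, the estimated step being a 2.5-fold higher number from compound 3 to compound 4 (0.40 log units; beyond the scatter). For compound 4 the estimated value is 40000 nM, with an expected range of 15000 nM to 100000 nM.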

Compound 4, half-maximal inhibitory concentration: 75000 nM
The estimate for compound 4 lay 1.9-fold (0.27 log units) below the measured number, within the range that was stated.
By their numbers in this assay, from the lowest: compound 3; then compounds 2 and 4 (each within the scatter of the next). At a limit, above all of these: compound 1.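

In this assay, 2-hydroxypropyl now keeps the lower number against a second carbonyl chain, (2-hydroxy-2-methylpentyl)carbonyl, with a 4.7-fold higher number from compound 3 to compound 4 (0.67 log units; beyond the scatter). With 1-hydroxy-1-methylbutyl in place of 1-hydroxypentyl on a saturated chain carbon bound to a carbonyl carbon, the result is a 1.7-fold higher number from compound 2 to compound 4 (0.22 log units; within the scatter), so the two carbonyl chains stay within the scatter of each other. Compound 1 reports only a limit: the limit of > 100000 nM in this assay, at which 1 of the 4 values shown sits. That limit leaves only a floor for the last step, an at least 1.3-fold lower number from compound 1 to compound 4 (0.12 log units; that floor lies within the scatter), and the true size of this step cannot be read.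

Open, from the compounds shown here alone, is how a longer chain on the 2-hydroxypropyl side would read. Also open, going by these compounds, is whether an amine or a carboxylic acid in place of that hydroxyl would keep the number of compound 3.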